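Replacing the sulfonyl methyl with pyrrolidine

The compounds below may be only part of what the source reports. "The series", "measured", "known", "first", "only" and "open" are said of these compounds alone.

Measured so far, all in a functional assay on HEK293 cells for antagonist activity at transient receptor potential cation channel subfamily V member 1 (Homo sapiens), read by calcium flux; a lower number here means a stronger inhibitor, a higher number a weaker inhibitor:

Compound 1, `FC(F)(F)c1ccc(Nc2cccc3sc(Nc4c(Cl)cccc4Cl)nc23)cc1`: its result is a limit of the assay, > 5000 nM.
Compound 2, `CSc1ccccc1Nc1nc2c(Nc3ccc(C(F)(F)F)cc3)ncnc2s1`: 43 nM.
Compound 3, `CS(=O)(=O)c1ccc(Nc2ncnc3sc(Nc4c(Cl)cccc4Cl)nc23)cc1`: 5 nM.

Compound 3 gives the lowest of the two numbers shown; compound 2 sits higher by a gap that lies beyond the usual scatter of this assay. Compound 1 does not give a number at all: the limit of > 5000 nM in this assay, at which 1 of the 3 values shown sits, so it can only be placed as weaker than the measured range, not compared in size with the other two.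

The next compound, compound 4, `O=S(=O)(c1ccc(Nc2ncnc3sc(Nc4c(Cl)cccc4Cl)nc23)cc1)N1CCCC1`, keeps everything in compound 3 and changes one spot: pyrrolidin-1-yl in place of methyl on a sulfonyl sulfur. In words, pyrrolidin-1-yl takes the place of methyl on the sulfonyl sulfur. Within the data shown here, no measured pair among the three compounds shows what such a change does here, so there is no step to lean on. The change adds a small saturated ring at a position that, in compound 3, already carries a sulfonyl group, and it touches no other part of the molecule. The expectation is a step of little size, none beyond the scatter or a slight loss.

Compound 4 is therefore expected to give about 10 nM, with a likely range from 3 nM to 40 nM. The step that this estimate implies, a 2.0-fold higher number from compound 3 to compound 4 (0.30 log units; within the scatter), is expected to remain modest.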

Compound 4, half-maximal inhibitory concentration: 1 nM
The estimate for compound 4 lay 10-fold (1.00 log units) above the measured number; measured number outside the range, below it.
By their numbers in this assay, from the lowest: compound 4; then compound 3; then compound 2. At a limit, above all of these: compound 1.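

Among these compounds, this is the first step that can be read at the sulfonyl sulfur, and in this assay it gives a 5.0-fold lower number from compound 3 to compound 4 (0.70 log units; beyond the scatter). At this position, then, a methyl can give way to the larger pyrrolidin-1-yl, with its five-membered non-aromatic ring, and the number falls by more than the usual scatter rather than rising. Nothing measured here accounts for that gain, so the reason for it remains unknown.

The step brings in a nitrogen on the sulfonyl sulfur and a ring together, so the compounds shown leave open which of the two matters: a dimethylamino group would keep the nitrogen without the ring, and a cyclopentyl group would keep a ring without the nitrogen. Also open, from the compounds shown here alone, is how far the ring itself can change, which a piperidine or a morpholine on the same sulfur would begin to show, and whether the same swap gives a similar step on a different core.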